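The compounds below may be only part of what the source reports. "The series", "measured", "known", "first", "only" and "open" are said of these compounds alone.

Compound 1 `c1ccc(CNC(c2ccc[nH]2)c2nnc(-c3ccccc3)o2)cc1`: 216000 nM
Compound 2 `Clc1cccc(-c2nnc(C(NCc3ccccc3)c3ccc[nH]3)o2)c1`: 56700 nM

Both numbers come from a functional assay on MCF7 cells (Homo sapiens) for cytotoxicity, read by MTT assay, with a stated time of 24 h; a higher number here means a weaker inhibitor, a lower number a stronger inhibitor. For the measured compounds named here, compound 2 gives the lower of the two numbers; its only neighbour is compound 1, separated by the step of a 3.8-fold lower number from compound 1 to compound 2 (0.58 log units; beyond the scatter), a modest shift brought by chloro in place of hydrogen on an aromatic carbon. Compound 3 `COc1ccc(-c2nnc(C(NCc3ccccc3)c3ccc[nH]3)o2)cc1` keeps the shared core of compound 2 and changes a single group: 4-methoxyphenyl in place of 3-chlorophenyl on an aromatic carbon. Going by the values given here, only the step from compound 1 to compound 2 bears on this change, and only partly: it tells how chloro in place of hydrogen moved the number, not what 4-methoxyphenyl does. Taking the chlorine away alone would be expected to undo that modest gain, while the 4-methoxyphenyl group has no measured precedent here. The expected step is therefore a 2.1-fold higher number from compound 2 to compound 3 (0.33 log units; beyond the scatter), toward a higher number, with wide uncertainty. Compound 3 is estimated at 120000 nM in this assay, within 40000 nM to 300000 nM.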

Compound 3, half-maximal inhibitory concentration: 461000 nM
Compound 3: middle estimate off by 3.8-fold (0.58 log units), on the low side; measured number outside the range, above it.
By their numbers in this assay, from the lowest: compound 2; then compound 1; then compound 3.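

In this assay, replacing 3-chlorophenyl with 4-methoxyphenyl gives an 8.1-fold higher number from compound 2 to compound 3 (0.91 log units; beyond the scatter), so this aromatic carbon of the five-membered ring responds clearly to a change in the attached aryl group. Compared with the plain phenyl group, the methoxy group gives a 2.1-fold higher number from compound 1 to compound 3 (0.33 log units; beyond the scatter), which shows that substitution on this phenyl ring can move the number in either direction: in these three compounds, chloro lowers it and methoxy raises it. No measurement available here explains this difference.

The chloro and methoxy groups differ in both identity and place on the phenyl ring, and the compounds shown cannot separate those two changes; 4-chlorophenyl and 3-methoxyphenyl would do so. On these data alone, how an amine or a carboxylic acid on this phenyl ring would move the number also remains open.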